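Fluoro in place of methoxy on compound 1

A few compounds are considered here, and "the series" means these few. Any claim that something is new, unique, unknown or untested is made for them only; others in the source may bear on it.

In an ADME assay on HEK-293T cells (Homo sapiens) for inhibition, read by CCK-8 assay, with a stated time of 48 h, tested at 20 uM (a lower number here means less inhibition of growth, a higher number more inhibition of growth at the concentration tested), compound 1 (`COc1ccc(Cc2nnc(NC(=O)/C(C#N)=C/c3ccccc3OS(=O)(=O)c3ccc([N+](=O)[O-])cc3)s2)cc1`) gives 17% and compound 2 (`COc1ccc(Cc2nnc(NC(=O)/C(C#N)=C/c3ccccc3OS(=O)(=O)c3ccccc3[N+](=O)[O-])s2)cc1`) gives 18%, which places the two level at the low end of the three numbers. Compound 3 (`COc1ccc(Cc2nnc(NC(=O)/C(C#N)=C/c3ccccc3OS(=O)(=O)c3ccc(Cl)cc3)s2)cc1`) stands apart at 34%. Compound 4 (`N#C/C(=C\c1ccccc1OS(=O)(=O)c1ccc([N+](=O)[O-])cc1)C(=O)Nc1nnc(Cc2ccc(F)cc2)s1`) carries fluoro in place of methoxy on an aromatic carbon, para to a large group: fluoro in place of methoxy on an aromatic carbon. For the measured compounds named here, no measured step changes this site. All three alter the group on the sulfonyl sulfur, so they offer only a guide to size: a number 1 percentage points higher from compound 1 to compound 2 (within the scatter), a number 17 percentage points higher from compound 1 to compound 3 (beyond the scatter) and a number 16 percentage points higher from compound 2 to compound 3 (beyond the scatter). The expected change is small, probably within the scatter, and the estimated step is a number 4 percentage points higher from compound 1 to compound 4 (within the scatter). Compound 4 is expected at 21%, with an estimated range of 8% to 36%.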

Compound 4, percent growth inhibition at one concentration: 8%
Beside the measured number, compound 4's estimate is 13 percentage points above it, within the range that was stated.
By their numbers in this assay, from the lowest: compounds 4, 1 and 2 (each within the scatter of the next); then compound 3.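

For the compounds shown here, compound 4 gives the only reading at the 4-methoxybenzyl end of compound 1: in this assay, fluoro in place of methoxy gives a number 9 percentage points lower from compound 1 to compound 4 (within the scatter). Going by these compounds alone, the earlier compounds changed only the group on the sulfonyl sulfur, where chloro in place of nitro moved the number beyond the scatter, whereas the one step at this position stays within it. Nothing measured here gives a cause for this result. From the compounds shown here alone, whether an amine or a carboxylic acid on this aromatic carbon would also stay level remains open, as does whether fluoro would behave the same way alongside the 4-chlorophenyl group of compound 3.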